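This account rests on a few compounds, and the source may have more. Where it says the series, first, only, none or still open, it means among the compounds named here.

Measured so far in an ADME assay on Karpas-1106P cells (Homo sapiens) for cytotoxicity; a lower number here means that less compound is needed, a higher number that more compound is needed for the effect:
- compound 1 `Cc1ccc(S(=O)(=O)N[C@@H](CC(=O)NC(C)(C)C)C(=O)NCCNC(=O)c2ccc(Cl)cc2)cc1`: > 11100 nM
- compound 2 `C#Cc1cccc(C(=O)NCCNC(=O)[C@H](CC(=O)NC(C)(C)C)NS(=O)(=O)c2ccc(C)cc2)c1`: > 11100 nM

Each of these two entries is a limit of the assay and not a number. Compound 2 stands at the limit of > 11100 nM in this assay, at which 2 of the 2 values shown sit, so its true place on the scale cannot be read, and neither can any ranking against compound 1.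

Compound 3 `Cc1ccc(S(=O)(=O)N[C@@H](CC(=O)NC(C)(C)C)C(=O)NCCNC(=O)c2ccccc2O)cc1` has not been measured yet. It carries 2-hydroxyphenyl in place of 3-ethynylphenyl on a carbonyl carbon.

Among the measured compounds shown here, the only measured step that bears on this change is a step that the two limits leave unreadable from compound 1 to compound 2. That step offers no size to carry over, so no change beyond the scatter is expected in this assay, in either direction. The expected size is a number no higher from compound 2 to compound 3 (the limit leaves the size open). The estimate for compound 3 is 11100 nM, with an expected range from 4000 nM to 25000 nM.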

Compound 3, half-maximal effective concentration: > 11100 nM
Compound 3 ended at the assay's limit; the forecaster's own chance of this, stated with the estimate: 85%; the middle value lies on the limit itself.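

In this assay compound 3 gives > 11100 nM, which is a limit and not a number. The steps to compound 3 from compound 1 and compound 2 cannot be read. The compounds shown leave open where each truly stands and whether swapping these groups changes anything.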